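The compounds below may be only part of what the source reports. "The series", "measured", "known", "first", "only" and "open" are said of these compounds alone.

Series notes. Compound 1 `O=C(Nc1ccc(Sc2nc3ccccc3s2)c(Cl)c1)c1ccccc1O`, compound 2 `COc1c(Br)cc(Br)cc1C(=O)Nc1ccc(Sc2nc3ccccc3s2)cc1` and compound 3 `COc1c(Br)cc(Br)cc1C(=O)Nc1ccc(Sc2nc3ccccc3s2)c(Cl)c1` share one core, with compound 3 combining the chloro of compound 1 and the acid-side group of compound 2. In an assay on isolated protein for inhibition of thiosulfate sulfurtransferase (Homo sapiens), with a stated time of 60 min, in the absence of a further agent (on this read-out higher numbers stand for weaker inhibition and lower numbers for stronger inhibition), compound 1 gives only a limit of the assay, > 100000 nM, and not a number. In this assay compound 2 likewise returns only a limit, > 100000 nM. Compound 3 also returns only a limit in this assay, > 100000 nM. Compound 3 therefore stands at the same limit as the other two, and the two single-point steps that lead to it are unreadable: a step that the two limits leave unreadable from compound 1 to compound 3 and a step that the two limits leave unreadable from compound 2 to compound 3. For the measured compounds named here, the one piece of evidence touching these steps is the limit of > 100000 nM in this assay, at which 3 of the 3 values shown sit.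

Compound 4 `O=C(Nc1ccc(Sc2nc3ccccc3s2)c(Cl)c1)c1cc(Br)cc(Br)c1` differs from compound 3 by hydrogen in place of methoxy on an aromatic carbon. Going by the values given here, no measured step in this assay covers a change of this kind, and the two steps into compound 3 give no readable size. With every value in the set at the limit, the expectation for compound 4 in this assay is that it too sits at or beyond that limit. The step this estimate means is expected to be a step that the limit leaves unreadable from compound 3 to compound 4. For compound 4 the estimated half-maximal inhibitory concentration in this assay is 150000 nM, with a range from 30000 nM to 1000000 nM.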

Compound 4, half-maximal inhibitory concentration: > 100000 nM
Compound 4: no number, only a limit; the forecaster's own chance of this, stated with the estimate: 80%; the middle value lies beyond the limit too.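

In this assay compound 4 gives > 100000 nM as a limit and not a number. Its steps from compound 1 and compound 3 therefore cannot be read. The compounds shown leave open whether any change on the shared core brings this inhibition to a measurable value: the limit of > 100000 nM in this assay, at which 4 of the 4 values shown sit.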